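A few compounds are considered here, and "the series" means these few. Any claim that something is new, unique, unknown or untested is made for them only; others in the source may bear on it.

Measured so far in an assay on HEK293 cells for positive allosteric modulation of metabotropic glutamate receptor 5 (Homo sapiens), read by FLIPR, with a stated time of 1 h; on this read-out higher numbers stand for an effect only at larger amounts of compound and lower numbers for an effect already at smaller amounts:

Compound 1, `Cc1cccc(C#Cc2nc3c(s2)C(=O)NCC3)c1`: > 10000 nM, a limit of the assay.
Compound 2, `Fc1cccc(C#Cc2nc3c(s2)CN(C2CCC2)CC3)c1`: > 10000 nM, a limit of the assay.
Compound 3, `CC(=O)N1CCc2nc(C#Cc3ccccc3)sc2C1`: > 10000 nM, a limit of the assay.

All three measured compounds sit at the limit of > 10000 nM in this assay, at which 3 of the 3 values shown sit, so none of them has a numerical half-maximal effective concentration in this assay. Compound 3 therefore stands nowhere in particular on the numbers shown: its value is a limit, and the two other values shown are limits of the same kind, so no ordering among the three can be read. For the measured compounds named here, no step between measured compounds can be taken, since no pair gives two numbers.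

The compound to be measured next is compound 4, `O=C(CC1CCOCC1)N1CCc2nc(C#Cc3ccccc3)sc2C1`. Against compound 3 it carries oxan-4-yl in place of hydrogen on a saturated chain carbon bound to a carbonyl carbon. Going by the values given here, the measured series gives no example of this kind of change at any position, and every value in it is a limit, so there is nothing to lean on for direction.

The step of a number no higher from compound 3 to compound 4 (the limit leaves the size open) is expected to stay within the scatter, with a better than even chance that compound 4 again reports only the limit. Compound 4 is estimated at 10000 nM in this assay, between 2000 nM and 40000 nM.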

Compound 4, half-maximal effective concentration: 470 nM
Compound 4: middle estimate off by 21-fold (1.33 log units), on the high side, and the stated range ends above it.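

In this assay, oxan-4-yl in place of hydrogen on a saturated chain carbon bound to a carbonyl carbon gives an at least 21-fold lower number from compound 3 to compound 4 (1.32 log units; beyond the scatter), and compound 4 holds the only numerical value among the compounds shown. This position therefore accepts a much larger group than the methyl of compound 3, and the same difference, read as methyl to (oxan-4-yl)methyl, is the one change shown that turns a limit into a number. Compound 3 remains a limit, so the full size of the step is unknown, and limits still make up most of the series: the limit of > 10000 nM in this assay, at which 3 of the 4 values shown sit.

The compounds shown do not separate the contribution of the ring oxygen from that of the ring as a whole, which a cyclohexyl group in the same place would address, and a piperidin-4-yl group with its ring amine or a longer chain to the carbonyl would probe how much of this group can vary. On these data alone, compound 1 and compound 2 differ from compound 4 in more than one place, so whether the effect of the change carries over to their other features stays open.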